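Hydroxyl position on the aryl arm in a pyridine series

The source may report more compounds than this note shows. Statements on the series, on what has been measured and on what is new or still open speak of the compounds shown alone.

Measured so far:
compound 1, `Oc1ccc(-c2cc(-c3ccco3)cc(-c3cccc(O)c3)n2)cc1`, 840 nM
compound 2, `Oc1ccc(-c2cc(-c3ccccn3)cc(-c3ccccc3O)n2)cc1`, > 50000 nM

In a functional assay on HCT-15 cells (Homo sapiens) for cytotoxicity, read by CCK-8 assay (on this read-out lower numbers stand for stronger inhibition and higher numbers for weaker inhibition), compound 1 gives 840 nM. For compound 2 only a limit is recorded, > 50000 nM, so compound 2 stands at the weak end of the numbers shown, as noted in the limit of > 50000 nM in this assay, at which 1 of the 2 values shown sits. Compound 3, `Oc1ccc(-c2cc(-c3ccccn3)cc(-c3cccc(O)c3)n2)cc1`, is not yet measured; it differs from compound 2 by 3-hydroxyphenyl in place of 2-hydroxyphenyl on an aromatic carbon. With compound 1, which also carries 3-hydroxyphenyl, at 840 nM, a gain beyond the scatter is expected from compound 2 to compound 3, of size an at least 10-fold lower number from compound 2 to compound 3 (1.00 log units; beyond the scatter). Compound 3 is estimated at 5000 nM, between 1000 nM and 40000 nM.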

Compound 3, half-maximal inhibitory concentration: > 50000 nM
Compound 3: a limit, no number; the forecaster's own chance of this, stated with the estimate: 25%; middle value at least 10-fold (1.00 log units) away from the limit.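

In this assay, pyridin-2-yl in place of furan-2-yl on an aromatic carbon gives an at least 59-fold higher number from compound 1 to compound 3 (1.77 log units; beyond the scatter), so the 3-hydroxyphenyl group shared with compound 1 does not by itself carry the activity. Compound 2 and compound 3 are both limits, and the step between them cannot be read. With pyridin-2-yl in the molecule, neither hydroxyphenyl arm gives a number, and compound 3 joins compound 2 at the limit: the limit of > 50000 nM in this assay, at which 2 of the 3 values shown sit.

Still open, on these data alone, is how 2-hydroxyphenyl reads alongside furan-2-yl. Also open, as far as these compounds go, is whether thiophen-2-yl or an amine in the furan-2-yl place would keep a measurable value.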